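Thiocarbamate chromones: morpholine for diisopropylamine in this series

The source may hold more compounds than are shown below. What is called first, only, known or untested is meant among the compounds shown, and "the series" means these compounds.

Measured so far:
compound 1, `O=c1cc(CSC(=S)N2CCOCC2)oc2cc(Cl)ccc12`, in a functional assay on MDA-MB-435S cells (Homo sapiens) for antiproliferative activity, read by MTT assay, with a stated time of 72 h (on this read-out higher numbers stand for weaker inhibition and lower numbers for stronger inhibition), a limit only: > 25000 nM
compound 2, `CC(C)N(C(=S)SCc1cc(=O)c2ccccc2o1)C(C)C`, in this assay a limit only: > 40000 nM

Compound 2 stands at a limit of this assay, so no number is known for it. Compound 3 `O=c1cc(CSC(=S)N2CCOCC2)oc2ccccc12` differs from compound 2 by morpholin-4-yl in place of diisopropylamino on a thiocarbonyl carbon. Since compound 1 carries the same morpholin-4-yl group and itself sits at a limit (the limit of > 25000 nM in this assay, at which 1 of the 2 values shown sits), no step beyond the scatter is expected. The expected step from compound 2 to compound 3 is a number no higher from compound 2 to compound 3 (the limit leaves the size open). Compound 3 is estimated at 40000 nM, within 10000 nM to 120000 nM, most likely reported again only as a limit.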

Compound 3, half-maximal inhibitory concentration: 22200 nM
Beside the measured number, compound 3's estimate is 1.8-fold (0.26 log units) above it; low and high end bracket the measured number.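

Among the compounds shown here, with morpholin-4-yl on the thiocarbonyl carbon and hydrogen on the aromatic carbon, compound 3 gives the first true number in this assay: 22200 nM. Morpholin-4-yl in place of diisopropylamino gives an at least 1.8-fold lower number from compound 2 to compound 3 (0.25 log units; that floor lies within the scatter), a floor only, as the starting value is a limit: the limit of > 40000 nM in this assay, at which 1 of the 3 values shown sits. Hydrogen in place of chloro gives an at least 1.1-fold lower number from compound 1 to compound 3 (0.05 log units; that floor lies within the scatter), again a floor only, as the starting value is a limit: the limit of > 25000 nM in this assay, at which 1 of the 3 values shown sits.

From the compounds shown here alone, the true size of either step stays open. Also open, going by these compounds, is whether piperidin-1-yl or dimethylamino on the thiocarbonyl carbon would give a lower number.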